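The source may report more compounds than this note shows. Statements on the series, on what has been measured and on what is new or still open speak of the compounds shown alone.

Measured so far in a functional assay on RAW264.7 cells (Mus musculus) for inhibition; on this read-out lower numbers stand for stronger inhibition and higher numbers for weaker inhibition
- compound 1 `CCOC(=O)C1=CCCCC1S(=O)(=O)Nc1ccccc1` gives 260 nM
- compound 2 `CCOC(=O)C1=CCCCC1S(=O)(=O)Nc1cccc(Cl)c1` gives 66 nM
- compound 3 `CCOC(=O)C1=CCCCC1S(=O)(=O)Nc1ccc(Cl)cc1` gives 400 nM

Among these three numbers, compound 1 lies within the scatter of compound 3 (a 1.5-fold higher number from compound 1 to compound 3 (0.19 log units; within the scatter)) and clearly apart from compound 2 (a 3.9-fold lower number from compound 1 to compound 2 (0.60 log units; beyond the scatter)).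

Compound 4 `CCOC(=O)C1=CCCCC1S(=O)(=O)Nc1ccccc1CC` has not yet been measured. Its change from compound 1 is ethyl in place of hydrogen on an aromatic carbon (ethyl in place of hydrogen on an aromatic carbon, ortho to a large group).

The nearest evidence is the pair of chloro in place of hydrogen steps, which are the same kind of change on an aromatic carbon. They do not agree: one is modest and the other stays within the scatter. Moving the chloro also counts (a 6.1-fold higher number from compound 2 to compound 3 (0.78 log units; beyond the scatter)), so the outcome differs between these two compounds with where the group sits. Within the data shown here, no measured compound carries ethyl, and none has a new group ortho to a large group, so the data give no direction. A step of modest size either way remains possible, but none beyond the scatter is the expectation in this assay.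

The expected step is small (a 1.4-fold lower number from compound 1 to compound 4 (0.16 log units; within the scatter)). For compound 4 the estimated value is 180 nM, with an expected range from 40 nM to 700 nM.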

Compound 4, half-maximal inhibitory concentration: 130 nM
The estimate for compound 4 lay 1.4-fold (0.14 log units) above the measured number, within the range that was stated.
By their numbers in this assay, from the lowest: compounds 2, 4, 1 and 3 (each within the scatter of the next, the first and the last beyond it).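

In this assay, ethyl in place of hydrogen on an aromatic carbon, ortho to a large group, gives a step that stays within the scatter (a 2.0-fold lower number from compound 1 to compound 4 (0.30 log units; within the scatter)), so no gain or loss can be claimed for this change. Among these compounds, this is the first reading at this place on the ring: a group of 2 carbon atoms, with no hydrogen-bond donor or acceptor, is accepted there without a change beyond the scatter, whereas the two chloro compounds spoke only to other places on the ring. No measurement shown explains why ethyl is accepted at this place.

A single group at this place cannot show how far the result extends: a longer chain such as butyl, or an amine or a carboxylic acid in the same place, could give a step of a different size or direction. Also open, as far as these compounds go, is whether chloro at this place would match ethyl, and whether ethyl at the two places that separated compound 2 from compound 3 would show the same split.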